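Three Compounds at the Assay Limit, One Still Untested

The source may hold more compounds than are shown below. What is called first, only, known or untested is meant among the compounds shown, and "the series" means these compounds.

Measured so far:
compound 1 `Fc1cccc(-c2nc(Nc3ccccc3)c3ccccc3n2)c1`: > 50000 nM
compound 2 `Fc1ccc2nc(-c3ccccc3)nc(Nc3ccccc3)c2c1`: > 50000 nM
compound 3 `COc1ccccc1Nc1nc(-c2cccc(F)c2)nc2ccc(F)cc12`: > 50000 nM

In a functional assay on HT29-AK cells (Homo sapiens) for cytotoxicity, read by MTT assay, with a stated time of 48 h (on this read-out lower numbers stand for stronger inhibition and higher numbers for weaker inhibition), compound 3 gives > 50000 nM, which is a limit of the assay rather than a number. Compound 1 likewise only reaches the limit > 50000 nM. Compound 2 also stops at the limit > 50000 nM. So all three measured compounds share the same fate: each sits at the limit of > 50000 nM in this assay, at which 3 of the 3 values shown sit, and none of them can be placed above or below another on these numbers. Compound 3 therefore stands exactly where its two companions stand, at the edge of what this assay can report.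

Compound 4 `Fc1cccc(-c2nc(Nc3ccc(Cl)cc3)c3cc(F)ccc3n2)c1` has not yet been measured. It differs from compound 3 by 4-chlorophenyl in place of 2-methoxyphenyl on a nitrogen on an aromatic ring. Within the data shown here, no pair of measured compounds differs in a single place, so there is no measured step to lean on; the only guide is that every measured compound, with three different patterns of substitution, sits at the same limit. The expectation is therefore no change beyond the scatter, with compound 4 most likely remaining at the limit. The step from compound 3 to compound 4 is expected to be a step that the limit leaves unreadable from compound 3 to compound 4. In this assay compound 4 is estimated at 60000 nM, with a likely range from 20000 nM to 200000 nM.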

Compound 4, half-maximal inhibitory concentration: 40300 nM
The estimate for compound 4 lay 1.5-fold (0.17 log units) above the measured number; measured number inside the range.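

In this assay, among these compounds, compound 4 gives 40300 nM, the first value in this set that is an actual number rather than a limit, which shows that a compound with a group at this place on the nitrogen can give a reading inside the range the assay reports. Putting 4-chlorophenyl in place of 2-methoxyphenyl gives an at least 1.2-fold lower number from compound 3 to compound 4 (0.09 log units; that floor lies within the scatter); this is only a floor, so the true step could be larger, but what is printed does not establish a real difference between the two compounds. A number for compound 4 is still a weak one on this read-out, and the other values offer no ranking of their own: the limit of > 50000 nM in this assay, at which 3 of the 4 values shown sit.

The change swaps both the group on the ring and where it sits, so the compounds shown cannot tell whether adding the chlorine, losing the methoxy group or the shift in position matters. As far as these compounds go, how an amine or a carboxylic acid on this ring would read, or a longer chain on the nitrogen in place of the ring, also stays open.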